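This account rests on a few compounds, and the source may have more. Where it says the series, first, only, none or still open, it means among the compounds named here.

In an ADME assay on HepG2 cells (Homo sapiens) for cytotoxicity, read by luminescence, with a stated time of 72 h (on this read-out lower numbers stand for an effect already at smaller amounts and higher numbers for an effect only at larger amounts of compound), three compounds sharing one core have been measured. Compound 1 (`CCOC(=O)c1c(-c2cccc(-c3ccccc3)c2)[nH]c2cc(OC)ccc2c1=O`) gives > 21500 nM as a limit of the assay and not a number. Compound 2 (`CCOC(=O)c1c(-c2cccc(OC(F)(F)F)c2)[nH]c2cc(OC)ccc2c1=O`) gives > 21500 nM as a limit too. Compound 3 (`CCOC(=O)c1c(-c2cccc(S(C)(=O)=O)c2)[nH]c2cc(OC)ccc2c1=O`) gives > 21500 nM as another limit. Compound 2 therefore stands at the limit of > 21500 nM in this assay, at which 3 of the 3 values shown sit, and cannot be ranked against the other two.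

Compound 4 (`CCOC(=O)c1c(-c2cccc(OC(F)(F)F)c2)[nH]c2cc(OC(F)(F)F)ccc2c1=O`) differs from compound 2 in one place: trifluoromethyl in place of methyl on an oxygen on an aromatic ring (methoxy to trifluoromethoxy).

The measured steps that could bear on this are a step that the two limits leave unreadable from compound 1 to compound 2 and a step that the two limits leave unreadable from compound 1 to compound 3 and also a step that the two limits leave unreadable from compound 2 to compound 3 so they offer no size to carry over. All three also change a different group from the one altered here. The expectation therefore rests on the shared limit alone, and compound 4 will most likely be reported as a limit as well. The estimated outcome is a step that the limit leaves unreadable from compound 2 to compound 4 with no clear direction expected. For compound 4 the estimated value is 30000 nM (expected range 12000 nM to 60000 nM).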

Compound 4, half-maximal effective concentration: > 21500 nM
Compound 4: a limit, no number; the forecaster's own chance of this, stated with the estimate: 80%; the middle value is on the limit's open side.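

Among the compounds shown here, compound 2 and compound 4 both give a limit of the assay and not a number, so the change from methoxy to trifluoromethoxy yields no step that can be read in this assay. The compounds shown leave open how all four rank against one another, as they share one value: the limit of > 21500 nM in this assay, at which 4 of the 4 values shown sit.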